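The compounds below may be only part of what the source reports. "The series", "measured", "known", "first", "only" and "open" are said of these compounds alone.

In a functional assay on MCF7 cells (Homo sapiens) for antiproliferative activity, read by MTT assay, with a stated time of 48 h (a lower number here means a stronger inhibitor, a higher number a weaker inhibitor), three compounds on a shared core have been measured. Compound 1 `CC(C)=CCC[C@]1(C)/C=C/[C@@H](OC(=O)C=C(C)C)[C@](C)(O)CCC(=O)/C(CO)=C\C1` reports only a limit, > 40000 nM. Compound 2 `CC(=O)O[C@@H]1/C=C/[C@@](C)(CCC=C(C)C)C/C=C(/CO)C(=O)/C=C/[C@@]1(C)O` gives 7890 nM, and compound 3 `CCCC(=O)O[C@@H]1/C=C/[C@@](C)(CCC=C(C)C)C/C=C(/CO)C(=O)/C=C/[C@@]1(C)O` gives 6040 nM. Compound 3 thus shares the measured range with compound 2, and their two numbers lie within the scatter of each other. Among the compounds with values here, the only measured step is a 1.3-fold lower number from compound 2 to compound 3 (0.12 log units; within the scatter), with ethyl in place of hydrogen on a saturated chain carbon bound to a carbonyl carbon. Compound 4 `COCO[C@@H]1/C=C/[C@@](C)(CCC=C(C)C)C/C=C(/CO)C(=O)/C=C/[C@@]1(C)O` brings a different kind of change, methoxymethyl in place of propylcarbonyl on an oxygen on a saturated carbon. Within the data shown here, the step to compound 3 keeps the carbonyl, so it bears only loosely on this replacement, and no measured step removes that carbonyl. In this assay, only a small move toward a higher number, not clearly beyond the scatter, is therefore expected. The expected change is a 1.5-fold higher number from compound 3 to compound 4 (0.17 log units; within the scatter). Compound 4 is estimated at 9000 nM, with an expected range from 3500 nM to 30000 nM.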

Compound 4, half-maximal inhibitory concentration: > 40000 nM
Compound 4: a limit, no number (the forecaster's own chance of this, stated with the estimate: 15%); at least 4.4-fold (0.64 log units) between middle value and limit.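

On an oxygen on a saturated carbon in this assay, methoxymethyl in place of propylcarbonyl gives an at least 6.6-fold higher number from compound 3 to compound 4 (0.82 log units; beyond the scatter), and methoxymethyl in place of acetyl gives an at least 5.0-fold higher number from compound 2 to compound 4 (0.70 log units; beyond the scatter). Within the data shown here, the earlier step changed only the chain on the carbonyl and stayed within the scatter, so these are the first steps at this position that lie beyond it, and here removing the carbonyl counts for more than that chain length did. Compound 4 gives only a limit, the same one as compound 1, which also carries an ester on this kind of oxygen but differs elsewhere, so an ester alone does not ensure a measurable number: the limit of > 40000 nM in this assay, at which 2 of the 4 values shown sit.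

On these data alone, how far compound 4 lies past its limit remains open. The compounds shown also do not tell whether a plain methyl or a benzoyl on this oxygen would behave like the esters or like compound 4.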